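This account rests on a few compounds, and the source may have more. Where it says the series, first, only, none or still open, it means among the compounds named here.

Compound 1 `N#Cc1c(-c2nnc(O)c3nn(-c4ccccc4)cc23)nn(-c2ccccc2)c1-c1ccccc1` carries a hydroxyl-bearing core, and in a functional assay on MDA-N cells (Homo sapiens) for inhibition, read by sulforhodamine B assay, with a stated time of 48 h (on this read-out higher numbers stand for weaker inhibition of growth and lower numbers for stronger inhibition of growth), compound 1 gives 13800 nM. Compound 2 `N#Cc1c(-c2nnc(O)c3nn(-c4ccc(Cl)cc4)cc23)nn(-c2ccccc2)c1-c1ccccc1` differs from it by chloro in place of hydrogen on an aromatic carbon, and this change gave an at least 7.2-fold higher number from compound 1 to compound 2 (0.86 log units; beyond the scatter). For compound 2 the value in this assay is only a limit, > 100000 nM, so the true size of that step is not known. Compound 3 `N#Cc1c(-c2nnc(-c3nn(-c4ccccc4)c(-c4ccccc4)c3C#N)c3nn(-c4ccccc4)cc23)nn(-c2ccccc2)c1-c1ccccc1` has a different core, in which a second nitrile-bearing ring system replaces the hydroxyl group; the difference between the two cores is not broken down here. In this assay compound 3 gives only a limit, > 100000 nM. Compound 4 `N#Cc1c(-c2nnc(-c3nn(-c4ccccc4)c(-c4ccccc4)c3C#N)c3nn(-c4ccc(Cl)cc4)cc23)nn(-c2ccccc2)c1-c1ccccc1` stands to compound 3 as compound 2 stands to compound 1, through the same change, (chloro in place of hydrogen on an aromatic carbon). Because the limit of > 100000 nM in this assay, at which 2 of the 3 values shown sit, already holds compound 3, and the same change weakened compound 1, compound 4 is expected to stay at that limit, and the step that the limit leaves unreadable from compound 3 to compound 4 is an estimate only. For compound 4 the expected value in this assay is 150000 nM, between 50000 nM and 600000 nM.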

Compound 4, concentration for 50% growth inhibition: 2260 nM
Compound 4: middle estimate off by 66-fold (1.82 log units), on the high side; measured number below the stated range.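

In this assay, the change from phenyl to 4-chlorophenyl gave an at least 44-fold lower number from compound 3 to compound 4 (1.64 log units; beyond the scatter), so on this core the chloro compound inhibits growth more strongly, and the change does not carry over from one core to the other with the same direction: the same change on two cores in this assay, an at least 7.2-fold higher number (0.86 log units; beyond the scatter) from compound 1 to compound 2 and an at least 44-fold lower number (1.64 log units; beyond the scatter) from compound 3 to compound 4, at least 320-fold (2.50 log units) apart, beyond the scatter of two such steps

The value of compound 3 is only a limit, > 100000 nM, so the true size of this step is not known. Two pairs on two cores show that the core can decide the direction of this change, but they do not show which part of the core is responsible, and they give no rule for a third core.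

The compounds shown leave open whether the reversal belongs to chloro alone or also appears with another group in the same place, such as fluoro, methoxy or an amine. Also open, going by these compounds, is how a carboxylic acid or an amine in place of the hydroxyl group on the core of compound 1 would respond to the same change.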